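This account rests on a few compounds, and the source may have more. Where it says the series, first, only, none or still open, it means among the compounds named here.

Measured so far:
Compound 1 `O=C(Nc1ccc(C(F)(F)F)cc1)c1cc(Cl)ccc1O`: 2800 nM
Compound 2 `O=C(Nc1cc(F)cc(F)c1)c1cc(Cl)ccc1O`: 6100 nM
Compound 3 `O=C(Nc1cc(F)cc(F)c1)c1cc(F)ccc1O`: 9600 nM

In an ADME assay on cells (Macrophage, Mus musculus) for cytotoxicity, read by resazurin assay, with a stated time of 3 days (on this read-out lower numbers stand for stronger inhibition and higher numbers for weaker inhibition), compound 1 gives the lowest of the three numbers, while compound 2 and compound 3 give higher ones. Compound 2 and compound 3 share a core and differ only by fluoro in place of chloro on an aromatic carbon; that change gave a 1.6-fold higher number from compound 2 to compound 3 (0.20 log units; within the scatter). How the core of compound 1 differs from the core of compound 2 is not broken down here.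

Compound 4 `O=C(Nc1ccc(C(F)(F)F)cc1)c1cc(F)ccc1O` has not yet been measured in this assay. It is derived from compound 1 by fluoro in place of chloro on an aromatic carbon, the same change as from compound 2 to compound 3. Because compound 1 gives 2800 nM and the change in that pair gave a 1.6-fold higher number from compound 2 to compound 3 (0.20 log units; within the scatter), a similarly small shift is expected: a 1.4-fold higher number from compound 1 to compound 4 (0.15 log units; within the scatter). The estimate for compound 4 is thus 4000 nM, expected to lie between 2000 nM and 8000 nM.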

Compound 4, half-maximal inhibitory concentration: 5400 nM
Compound 4: middle estimate off by 1.4-fold (0.13 log units), on the low side; the measured number falls inside the stated range.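

In this assay, fluoro in place of chloro gave a 1.9-fold higher number from compound 1 to compound 4 (0.29 log units; within the scatter), a step small enough to be ordinary variation between repeat measurements. Set beside the earlier step, the two cores agree: the same change on two cores in this assay, a 1.6-fold higher number (0.20 log units; within the scatter) from compound 2 to compound 3 and a 1.9-fold higher number (0.29 log units; within the scatter) from compound 1 to compound 4, 1.2-fold (0.09 log units) apart, within the scatter of two such steps. The change therefore carries across these two cores with no visible difference, but two pairs are a thin basis for a rule, and with both steps within the scatter, neither pair shows that the swap really moves the number at all.

Still open, going by these compounds, is whether another group in the same place, such as a methyl, a methoxy or a nitrile, would give a step beyond the scatter. Also open, on these data alone, is whether an amine in place of the hydroxy group would shift the number.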